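The compounds below may be only part of what the source reports. "The series", "measured", "known", "first", "only" and "open" are said of these compounds alone.

Of the compounds shown here, three have so far been measured in an assay on isolated protein for inhibition of activin receptor type-2A (Homo sapiens), read by 33P incorporation, with a stated time of 20 min, in the presence of a further agent that is not named here; on this read-out lower numbers stand for stronger inhibition and higher numbers for weaker inhibition. Compound 1 `C=Cc1cn2ncc(-c3ccnc(OC)c3)c2nc1NC` gives 190 nM. Compound 2 `COc1cc(-c2cnn3cc(OC)c(C(C)C)nc23)ccn1` gives 3800 nM, the highest of the three numbers. Compound 3 `Cn1cc(-c2nc3c(-c4ccnc(OC5CC5)c4)cnn3cc2OCCCC(C)(C)O)cn1` gives 2900 nM, which lies within the usual scatter of compound 2, so these two cannot be told apart, whereas compound 1 sits far below both, beyond the scatter. Compound 4 `CCc1nc2c(-c3ccnc(OC)c3)cnn2cc1OC` has not yet been measured. It differs from compound 2 by hydrogen in place of methyl on a saturated chain carbon bound to an aromatic carbon and a saturated chain carbon. Going by the values given here, no pair of measured compounds differing in a single place shows how such a change behaves here, so the expectation rests on compound 2 alone. A step of a 1.3-fold lower number from compound 2 to compound 4 (0.10 log units; within the scatter) is expected, not beyond the scatter in either direction. Compound 4 is therefore estimated at 3000 nM, with a range from 1200 nM to 8000 nM.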

Compound 4, half-maximal inhibitory concentration: 960 nM
Estimate against measurement, compound 4: 3.1-fold (0.49 log units) above; the measured number lies below the stated range.
By their numbers in this assay, from the lowest: compound 1; then compound 4; then compounds 3 and 2 (each within the scatter of the next).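

Shortening isopropyl to ethyl, on a saturated chain carbon bound to an aromatic carbon and a saturated chain carbon, gives a 4.0-fold lower number from compound 2 to compound 4 (0.60 log units; beyond the scatter) in this assay. Going by these compounds alone, this is the first comparison here that changes a single place, and it shows that this position responds to the loss of one methyl, with the smaller ethyl group going with stronger inhibition. No measurement shown explains this difference. From the compounds shown here alone, whether an even smaller group, a longer chain such as butyl, or an amine at this position would lower the number further remains open. So does whether the same change would have a similar effect on the other compounds' different substituents.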